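Amine variation at the chain end of the shared core

The compounds below may be only part of what the source reports. "The series", "measured", "known", "first", "only" and "open" are said of these compounds alone.

Measured so far in an assay on isolated protein (Cavia porcellus) with Sigma non-opioid intracellular receptor 1 (Homo sapiens) as the target, read by radioligand binding; on this read-out lower numbers stand for stronger inhibition and higher numbers for weaker inhibition:
compound 1 `CN(C)CCCCCCCCOc1ccc2oc(-c3ccccc3)cc(=O)c2c1` gives 227 nM
compound 2 `O=c1cc(-c2ccccc2)oc2ccc(OCCCCCCN3CCCCC3)cc12` gives 101 nM

Going by the values given here, compound 2 holds the lower of the two numbers in this assay, and the single measured step, a 2.2-fold lower number from compound 1 to compound 2 (0.35 log units; beyond the scatter), is all the series offers so far. Compound 3 `CN(CCCCCCOc1ccc2oc(-c3ccccc3)cc(=O)c2c1)Cc1ccccc1` has not yet been measured. It differs from compound 2 by benzyl(methyl)amino in place of piperidin-1-yl on a saturated chain carbon, six bonds along the chain from an oxygen on an aromatic ring. Among the compounds with values here, no measured step exchanges these two groups; the one known step touches the same chain end but a different pair of amines and was modest in size. With nothing closer to lean on, the expected outcome is a 1.1-fold lower number from compound 2 to compound 3 (0.05 log units; within the scatter), that is, no movement beyond the scatter in either direction. Compound 3 is accordingly estimated at 90 nM, within a range from 30 nM to 300 nM.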

Compound 3, half-maximal inhibitory concentration: 52 nM
The estimate for compound 3 lay 1.7-fold (0.24 log units) above the measured number; low and high end bracket the measured number.
By their numbers in this assay, from the lowest: compounds 3 and 2 (each within the scatter of the next); then compound 1.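

In this assay, the exchange of piperidin-1-yl for benzyl(methyl)amino at this chain end, a 1.9-fold lower number from compound 2 to compound 3 (0.29 log units; within the scatter), stays within the scatter, so this position accepts a six-membered aromatic ring of carbon only, carried on the benzyl group, without a change that can be read, just as it accepts the six-membered non-aromatic ring. The step of a 4.4-fold lower number from compound 1 to compound 3 (0.64 log units; beyond the scatter) lies beyond the scatter and, read with compound 2, leaves compound 1 with its 2-(dimethylamino)ethyl group apart from the two ring-bearing amines, with no listed compound going against this. Nothing available explains either step.

The compounds shown leave open how a morpholin-4-yl or a 4-benzylpiperidin-1-yl group would read at this chain end. They also leave open whether benzyl(methyl)amino would hold its number on a shorter chain.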